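A few compounds are considered here, and "the series" means these few. Any claim that something is new, unique, unknown or untested is made for them only; others in the source may bear on it.

Working notes on the series. In an assay on HEK293 cells for inhibition of Steryl-sulfatase (Homo sapiens), tested at 1 uM (on this read-out lower numbers stand for a weaker effect and higher numbers for a stronger effect at the one concentration tested), compound 1 `CN(CCCN1CCCCC1)c1ccc(C(=O)N2CCc3ccc(OS(N)(=O)=O)cc3C2)cc1` gives 40.7%, the highest of the two numbers measured. Compound 2 `NS(=O)(=O)Oc1ccc2c(c1)CN(C(=O)c1cccc(N3CCN(c4ncccn4)CC3)c1)CC2` gives 24.4% in this assay, a gap beyond the scatter. Among the compounds with values here, no step between measured compounds follows a single change, so compound 3 `CC(C)CCN(CCC(C)C)c1ccc(C(=O)N2CCc3ccc(OS(N)(=O)=O)cc3C2)cc1` rests on the change alone: diisopentylamino in place of methyl(3-(piperidin-1-yl)propyl)amino on an aromatic carbon. With nothing measured that bears on this change, a step within the scatter or a small fall is expected, and the step of a number 5.7 percentage points lower from compound 1 to compound 3 (within the scatter) is taken as the estimate. For compound 3 the expected value in this assay is 35%, in a range from 15% to 58%.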

Compound 3, a percentage reported as inhibition, at one concentration (the size of the read-out at that concentration, not a potency): 90.8%
Compound 3: middle estimate off by 55.8 percentage points, on the low side; measured number outside the range, above it.
By their numbers in this assay, from the lowest: compound 2; then compound 1; then compound 3.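

At this position, on an aromatic carbon para to a large group, diisopentylamino in place of methyl(3-(piperidin-1-yl)propyl)amino gives, in this assay, a number 50.1 percentage points higher from compound 1 to compound 3 (beyond the scatter). The read-out therefore responds strongly to this group, and a high number needs neither a ring nor a second nitrogen in it. No measured evidence bears on what lies behind this step.

Which part of the change carries the step stays open: the branched chains, the loss of the ring, or the loss of the second nitrogen. A dipentylamino or a dipropylamino group at this position would start to separate chain branching from chain length.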